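This account rests on a few compounds, and the source may have more. Where it says the series, first, only, none or still open, it means among the compounds named here.

Measured compounds in an assay on membranes from striatum (strain Sprague-Dawley) for displacement of a labelled ligand from sodium-dependent dopamine transporter (Rattus norvegicus), read by scintillation counting, with a stated time of 120 min; on this read-out higher numbers stand for weaker inhibition and lower numbers for stronger inhibition:
- compound 1 `Fc1ccc(C(SCCNC2CCN(Cc3ccc(Cl)cc3)CC2)c2ccc(F)cc2)cc1`: 39.6 nM
- compound 2 `[O-][S+](CCNC1CCN(CC(O)Cc2ccccc2)CC1)C(c1ccc(F)cc1)c1ccc(F)cc1`: 91.8 nM
- compound 3 `O=C(c1ccccc1)N1CCC(NCCSC(c2ccc(F)cc2)c2ccc(F)cc2)CC1`: 4.51 nM

Compound 1 stands second highest of the three numbers in this assay. Compound 2 gives the higher number of the two, and compound 3 the lowest of the set, so compound 1 sits between them, nearer to compound 2.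

Compound 4 `O=C(c1ccc(F)cc1)N1CCC(NCCSC(c2ccc(F)cc2)c2ccc(F)cc2)CC1` is not yet measured. It differs from compound 1 by (4-fluorophenyl)carbonyl in place of 4-chlorobenzyl on an amine nitrogen in a ring.

For the measured compounds named here, the one measured step that bears on this change is an 8.8-fold lower number from compound 1 to compound 3 (0.94 log units; beyond the scatter), where a benzoyl replaced the same 4-chlorobenzyl on the same ring nitrogen. Going by the values given here, compound 4 carries the same carbonyl link to an aromatic ring, with a fluorine added on that ring; no measured pair shows the effect of that fluorine alone. That measured step sets the direction and about the size to be followed here. The expected step is accordingly a 7.2-fold lower number from compound 1 to compound 4 (0.86 log units; beyond the scatter).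

Compound 4 is estimated at 5.5 nM in this assay, with a range of 2 nM to 15 nM.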

Compound 4, inhibition constant: 7.04 nM
Compound 4: middle estimate off by 1.3-fold (0.11 log units), on the low side, within the range that was stated.
By their numbers in this assay, from the lowest: compounds 3 and 4 (each within the scatter of the next); then compound 1; then compound 2.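

In this assay, a second carbonyl-linked group in place of 4-chlorobenzyl on the ring nitrogen also lowers the number, a 5.6-fold lower number from compound 1 to compound 4 (0.75 log units; beyond the scatter), so the drop seen with benzoyl, an 8.8-fold lower number from compound 1 to compound 3 (0.94 log units; beyond the scatter), now holds for two such groups rather than one. Fluoro in place of hydrogen on an aromatic carbon of the benzoyl group gives a 1.6-fold higher number from compound 3 to compound 4 (0.19 log units; within the scatter), within the scatter, so this fluorine brings no readable change at this position. Nothing at hand accounts for the lower numbers of the carbonyl-linked groups.

Still open, on these data alone, is how a 4-fluorobenzyl group on the same nitrogen would compare with compound 4, which would separate the carbonyl from the ring substituent. Also open, as far as these compounds go, is whether a methanesulfonyl or acetyl group there would keep the lower number.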